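Imidazoline analogues: pyridine to pyrimidine at the imine carbon

A few compounds are considered here, and "the series" means these few. Any claim that something is new, unique, unknown or untested is made for them only; others in the source may bear on it.

Measured compounds:
- compound 1 `Cc1cccc(C2=NC(c3ccc(F)cc3)(c3ccc(F)cc3)CN2)c1` gives 30 nM in an assay on LM cells for displacement of a labelled ligand from Neuropeptide Y receptor type 5 (Homo sapiens); a lower number here means a stronger inhibitor, a higher number a weaker inhibitor
- compound 2 `Fc1ccc(C2(c3ccc(F)cc3)CNC(c3cccs3)=N2)cc1` gives 54 nM in this assay
- compound 3 `Fc1ccc(C2(c3ccc(F)cc3)CNC(c3cccnc3)=N2)cc1` gives 7.2 nM in this assay

Three compounds share one core and differ only in the aromatic group attached to the carbon that carries a double bond to nitrogen. Compound 3 has the lowest number of the three: compound 1 stands nearest, a 4.2-fold lower number from compound 1 to compound 3 (0.62 log units; beyond the scatter), and compound 2 furthest, a 7.5-fold lower number from compound 2 to compound 3 (0.88 log units; beyond the scatter). The step from compound 1 to compound 2 is a 1.8-fold higher number from compound 1 to compound 2 (0.26 log units; within the scatter).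

Compound 4 `Fc1ccc(C2(c3ccc(F)cc3)CNC(c3cncnc3)=N2)cc1` has not yet been measured in this assay. It differs from compound 3 by one change: pyrimidin-5-yl in place of pyridin-3-yl on a carbon with a double bond to nitrogen. The two steps that bear on this are the ones that led into compound 3, a 4.2-fold lower number from compound 1 to compound 3 (0.62 log units; beyond the scatter) and a 7.5-fold lower number from compound 2 to compound 3 (0.88 log units; beyond the scatter), both gains from putting pyridin-3-yl in place. Whether a second ring nitrogen continues that trend or reverses it cannot be read from these three compounds. The expectation for compound 4 is therefore a step near the scatter, a 1.7-fold higher number from compound 3 to compound 4 (0.22 log units; within the scatter), with a slight lean towards a higher number. For compound 4 the estimated value in this assay is 12 nM, with a range from 4 nM to 40 nM.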

Compound 4, half-maximal inhibitory concentration: 47 nM
Estimate against measurement, compound 4: 3.9-fold (0.59 log units) below; the whole stated range lies below it.
By their numbers in this assay, from the lowest: compound 3; then compounds 1, 4 and 2 (each within the scatter of the next).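

At the carbon with a double bond to nitrogen, adding ring nitrogen does not keep improving the result: in this assay, pyrimidin-5-yl in place of pyridin-3-yl reverses the earlier gain (a 6.5-fold higher number from compound 3 to compound 4 (0.81 log units; beyond the scatter)). The gain is lost entirely, since pyrimidin-5-yl cannot be told apart from either thiophen-2-yl (a 1.1-fold lower number from compound 2 to compound 4 (0.06 log units; within the scatter)) or 3-methylphenyl (a 1.6-fold higher number from compound 1 to compound 4 (0.19 log units; within the scatter)). Pyridin-3-yl therefore stands alone among these four groups, and this position is sensitive enough for a change of one ring atom, with the count of 6 heavy atoms unchanged, to separate compound 3 from compound 4.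

Nothing here gives a measured reason for this reversal. The compounds shown also leave open whether the number of ring nitrogen atoms or their place in the ring matters more, a question that pyridin-4-yl, pyridin-2-yl or a plain phenyl ring at this carbon could help to answer.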